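Adding 1-Ethoxyethenyl to the Aromatic Ring of Compound 1

This account rests on a few compounds, and the source may have more. Where it says the series, first, only, none or still open, it means among the compounds named here.

Compound 1 `O=C1CCC(N2C(=O)c3cccc(Nc4ccccc4)c3C2=O)C(=O)N1`: 4%
Compound 2 `CN(c1ccccc1)c1ccc2c(c1)C(=O)N(C1CCC(=O)NC1=O)C2=O`: -2%
Compound 3 `Cc1ccc(Nc2ccc3c(c2)C(=O)N(C2CCC(=O)NC2=O)C3=O)cc1`: 5%

In an assay on FRT-Jurkat cells for inhibition of nuclear factor NF-kappa-B complex (Homo sapiens), read by flow cytometry, with a stated time of 24 h, tested at 10 uM (on this read-out lower numbers stand for less inhibition and higher numbers for more inhibition at the one concentration tested (going by the name of the read-out)), compound 1 gives 4%, the second highest of the three numbers, and all three lie within the scatter of one another. Among the measured compounds shown here, the only step between measured compounds, a number 7 percentage points higher from compound 2 to compound 3 (within the scatter), concerns a different change and is itself within the scatter. Compound 4 `C=C(OCC)c1ccc(Nc2cccc3c2C(=O)N(C2CCC(=O)NC2=O)C3=O)cc1` differs from compound 1 by 1-ethoxyethenyl in place of hydrogen on an aromatic carbon. For the measured compounds named here, no measured step bears on this change, so nothing in the data points to a step beyond the scatter in this assay. Compound 4 is therefore expected to give 5% (range -10% to 20%), which means an estimated step of a number 1 percentage points higher from compound 1 to compound 4 (within the scatter).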

Compound 4, a percentage reported as inhibition, at one concentration (the size of the read-out at that concentration, not a potency): 10%
For compound 4 the middle estimate is 5 percentage points below the measured one; measured number inside the range.
By their numbers in this assay, from the lowest: compounds 2, 1, 3 and 4 (each within the scatter of the next, the first and the last beyond it).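

In this assay, 1-ethoxyethenyl in place of hydrogen on this aromatic carbon gives a number 6 percentage points higher from compound 1 to compound 4 (within the scatter). Compound 1 carries only hydrogen at this place, so the pair adds one finding: a group with no ring and a double bond outside aromatic rings can stand para to the large group without a step beyond the scatter. As far as these compounds go, whether an amine, a carboxylic acid or a longer chain at this place would give a step beyond the scatter stays open. No measurement bearing on the reason for this result is available.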